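The source may hold more compounds than are shown below. What is called first, only, known or untested is meant among the compounds shown, and "the series" means these compounds.

Values in an ADME assay on TERT-RPE1 cells (Homo sapiens) for cytotoxicity, read by MTT assay, with a stated time of 72 h; on this read-out higher numbers stand for weaker inhibition and lower numbers for stronger inhibition:
- compound 1 `COc1ccc(/C=C2/CN(C)/C(=N/c3ccc(C)cc3)S2)cc1` gives 65700 nM
- compound 2 `COc1ccc(/C=C2\S/C(=N\c3ccc(C)c(Cl)c3)N(C)C2=O)cc1` gives 23000 nM
- compound 3 `COc1ccc(/C=C2\S/C(=N\c3cc(C(F)(F)F)cc(C(F)(F)F)c3)N(C)C2=O)cc1` gives > 100000 nM (a limit, not a number)

Among the two actual numbers, compound 1 stands highest, and compound 2, the nearest, lies lower by more than the scatter. Compound 3 gives only a limit. Compound 4 `COc1ccc(/C=C2/CN(C)/C(=N/c3ccc(Cl)cc3)S2)cc1` carries chloro in place of methyl on an aromatic carbon, para to a large group, relative to compound 1 (chloro in place of methyl on an aromatic carbon). Among the measured compounds shown here, no measured step shows this exchange, so the expectation starts from compound 1 at 65700 nM and foresees no change beyond the scatter. The expected step is a 1.3-fold lower number from compound 1 to compound 4 (0.12 log units; within the scatter), slightly lower if anything. For compound 4 the estimated value is 50000 nM, with an expected range from 20000 nM to 100000 nM.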

Compound 4, half-maximal inhibitory concentration: 39600 nM
Beside the measured number, compound 4's estimate is 1.3-fold (0.10 log units) above it; measured number inside the range.
By their numbers in this assay, from the lowest: compounds 2, 4 and 1 (each within the scatter of the next, the first and the last beyond it). At a limit, above all of these: compound 3.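

In this assay, the exchange 4-methylphenyl to 4-chlorophenyl gives a 1.7-fold lower number from compound 1 to compound 4 (0.22 log units; within the scatter), so chloro in place of methyl on an aromatic carbon, para to a large group, stays within the scatter on the core of compound 1. Among the compounds shown here, the earlier compounds held no pair differing in one place, so this is the only single change readable. Nothing measured here gives a cause for this step.

Open: whether an amine or a carboxylic acid at this place would move the number beyond the scatter, and whether the same exchange behaves alike on the core of compound 2.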